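The source may report more compounds than this note shows. Statements on the series, on what has been measured and on what is new or still open speak of the compounds shown alone.

Measured so far:
compound 1 `COc1cc2c(cc1C)NC(=O)/C2=C/c1c(OC)nc2sc(C)cn12` — 74900 nM
compound 2 `O=C1Nc2ccccc2C1=Cc1c(-c2ccncc2)nc2sccn12` — 82400 nM

Both numbers come from a functional assay on NSCLC cells (Homo sapiens) for cytotoxicity, read by sulforhodamine B assay, with a stated time of 48 h; a lower number here means a stronger inhibitor of growth, a higher number a weaker inhibitor of growth. In this assay compound 1 gives 74900 nM and compound 2 gives 82400 nM; the two values lie within the scatter of each other, so compound 1 cannot be set apart from compound 2 on these two numbers, and both sit in the weak range of the read-out. Among the compounds with values here, compound 2 carries a different substituent on the shared core, so no single-point step between the measured compounds is available.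

The next compound, compound 3 `COc1ccc2c(c1)/C(=C\c1c(OC)nc3sc(C)cn13)C(=O)N2`, is reached from compound 1 by one change: hydrogen in place of methyl on an aromatic carbon. The methoxy group on the same ring, the fused amide ring and the remaining core of compound 1 are untouched.

Within the data shown here, no measured pair isolates this change, so the step from compound 1 to compound 3 in this assay cannot be anchored. With one heavy atom removed and nothing entering, the expectation is for no shift beyond the scatter, in either direction; the estimated step is a 1.1-fold higher number from compound 1 to compound 3 (0.03 log units; within the scatter). Compound 3 is expected to give about 80000 nM, within 35000 nM to 180000 nM.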

Compound 3, concentration for total growth inhibition: 58700 nM
For compound 3 the middle estimate is 1.4-fold (0.13 log units) above the measured one; measured number inside the range.
By their numbers in this assay, from the lowest: compounds 3, 1 and 2 (each within the scatter of the next).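

In this assay, within the data shown here, hydrogen in place of methyl, on the aromatic carbon ortho to a methoxy group, gives a 1.3-fold lower number from compound 1 to compound 3 (0.11 log units; within the scatter) and so provides the first single-place comparison. At this position, the methyl group cannot be told apart from hydrogen on these numbers, and with the methoxy group, the fused amide ring and the rest of the shared core held constant, compound 1 and compound 3 both stay in the weak range of the read-out. Nothing on hand gives a reason for this result.

From the compounds shown here alone, the step covers one heavy atom only, so it remains open whether this aromatic carbon responds at all to a larger or different substituent, such as an amine, a carboxylic acid, a chlorine atom or a longer chain. Also open, going by these compounds, is whether the methoxy group on the same ring contributes to the values seen, and whether a group such as a hydroxyl or an ethoxy group in its place would move the number beyond the scatter.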